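A few compounds are considered here, and "the series" means these few. Any claim that something is new, unique, unknown or untested is made for them only; others in the source may bear on it.

Compound 1, with the structure `O=C(O)/C=C/c1ccncc1-c1ccc2ccccc2c1`, is a cinnamic acid bearing a naphthyl ring on its pyridine core. In a functional assay on A549 cells (Homo sapiens) for inhibition, read by sulforhodamine B assay, with a stated time of 72 h (on this read-out lower numbers stand for stronger inhibition of growth and higher numbers for weaker inhibition of growth), compound 1 reaches only the limit of the measurement, giving > 10000 nM. Compound 2, with the structure `Cn1ncc2cc(-c3cnccc3/C=C/C(=O)O)ccc21`, carries a methylindazolyl group instead, and in this assay compound 2 likewise returns only a limit, > 10000 nM. Both values therefore sit at the limit of > 10000 nM in this assay, at which 2 of the 2 values shown sit, so compound 1 stands at the weak end of what was shown, with no number to rank it. Compound 3, with the structure `NC(=O)/C=C/c1ccncc1-c1ccc2ccccc2c1`, differs from compound 1 by the change (amino in place of hydroxy on a carbonyl carbon). For the measured compounds named here, since no measured step accompanies this change, only a modest move is expected, an at least 1.2-fold lower number from compound 1 to compound 3 (0.09 log units; that floor lies within the scatter), and compound 3 is estimated at 8000 nM, within 2000 nM to 30000 nM.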

Compound 3, concentration for 50% growth inhibition: > 10000 nM
Compound 3: only a limit was reported; the forecaster's own chance of this, stated with the estimate: 55%; at least 1.2-fold (0.09 log units) between middle value and limit.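

Compound 3 returns only a limit, > 10000 nM. Compound 1 also stands at a limit, so no step can be read between compound 1 and compound 3: the limit of > 10000 nM in this assay, at which 3 of the 3 values shown sit.

The compounds shown leave open whether amino in place of hydroxy on a carbonyl carbon changes growth inhibition at all.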